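A few compounds are considered here, and "the series" means these few. Any claim that something is new, unique, unknown or untested is made for them only; others in the source may bear on it.

Measured so far in an assay on HEK293 cells for agonist activity at Toll-like receptor 8 (Homo sapiens), read by a luciferase reporter, with a stated time of 6 h; a higher number here means that more compound is needed for the effect, a lower number that less compound is needed:
compound 1, `CCCCNc1nc(N)nc2c1CN(Cc1ccccc1)CC2`, 0.06 uM
compound 2, `CCCCNc1nc(N)nc2c1CN(Cc1ccc(C(F)(F)F)cc1)CC2`, 0.23 uM
compound 3, `CCCCNc1nc(N)nc2c1CN(Cc1ccc(C(C)(C)C)cc1)CC2`, 0.66 uM

Compound 3 gives the highest of the three numbers; compound 2 stands nearest and compound 1 furthest. Compound 4, `CCCCNc1nc(N)nc2c1CN(Cc1ccc(-c3ccccc3)cc1)CC2`, differs from compound 3 in one place: phenyl in place of tert-butyl on an aromatic carbon. Among the measured compounds shown here, the steps that bear on this are those that placed a group on that aromatic carbon, a 3.8-fold higher number from compound 1 to compound 2 (0.58 log units; beyond the scatter) and an 11-fold higher number from compound 1 to compound 3 (1.04 log units; beyond the scatter), with a 2.9-fold higher number from compound 2 to compound 3 (0.46 log units; beyond the scatter) showing tert-butyl raising the number more than trifluoromethyl. Each group on that carbon raised the number. Phenyl, counted as six heavy atoms, is expected to behave much like tert-butyl, so no step beyond the scatter, or at most a small further rise, is expected in this assay: a 1.5-fold higher number from compound 3 to compound 4 (0.18 log units; within the scatter). Compound 4 is estimated at 1 uM, ranging from 0.3 uM to 3 uM.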

Compound 4, minimum effective concentration: 0.5 uM
The estimate for compound 4 lay 2.0-fold (0.30 log units) above the measured number; measured number inside the range.
By their numbers in this assay, from the lowest: compound 1; then compound 2; then compounds 4 and 3 (each within the scatter of the next).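

In this assay, putting phenyl in place of tert-butyl on the aromatic carbon gives a 1.3-fold lower number from compound 3 to compound 4 (0.12 log units; within the scatter), so a ring of carbon only and a group with no ring cannot be told apart at this position. Phenyl still stands apart from trifluoromethyl, with a 2.2-fold higher number from compound 2 to compound 4 (0.34 log units; beyond the scatter), and from hydrogen, with an 8.3-fold higher number from compound 1 to compound 4 (0.92 log units; beyond the scatter), so hydrogen keeps the lowest number of the four compounds. Nothing available explains why these groups give these numbers. Still open, from the compounds shown here alone, is how an amine, a carboxylic acid or a methoxy group on that carbon would compare with hydrogen.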